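This account rests on a few compounds, and the source may have more. Where it says the series, first, only, none or still open, it means among the compounds named here.

Measured in a functional assay on A549 cells (Homo sapiens) for antiproliferative activity, read by CCK-8 assay, with a stated time of 72 h; a higher number here means a weaker inhibitor, a lower number a stronger inhibitor:
compound 1 `CCOc1cc(C(C)(C)C)ccc1C1=NC(c2ccc(Cl)cc2)C(c2ccc(Cl)cc2)N1C(=O)NCCCCCCCC(=O)NO`: 4850 nM
compound 2 `CCOc1cc(C(C)(C)C)ccc1C1=NC(c2ccc(Cl)cc2)C(c2ccc(Cl)cc2)N1C(=O)NCCCCCC(=O)Nc1ccccc1N`: 20300 nM

Compound 2 carries the higher number of the two, at the weak end of this small set. The next entry is compound 3 `CCOc1cc(C(C)(C)C)ccc1C1=NC(c2ccc(Cl)cc2)C(c2ccc(Cl)cc2)N1C(=O)NCCCCC(=O)Nc1ccccc1N`, with the change ((2-aminophenyl)carbamoyl in place of ((2-aminophenyl)carbamoyl)methyl on a saturated chain carbon, four bonds along the chain from an amide-type nitrogen). It keeps the (2-aminophenyl)carbamoyl end and alters only the chain, on a saturated chain carbon, four bonds along the chain from an amide-type nitrogen.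

Among the measured compounds shown here, only one measured step bears on this, and only indirectly. The modest 4.2-fold higher number from compound 1 to compound 2 (0.62 log units; beyond the scatter) replaces the end group as well as altering the chain, so it sets a rough scale at most. For the measured compounds named here, no measured step isolates the chain alone, and the data favour no direction. No change beyond the scatter is therefore expected, and the estimated step is a 1.0-fold lower number from compound 2 to compound 3 (0.01 log units; within the scatter). For compound 3 the estimated value is 20000 nM, with an expected range from 9000 nM to 45000 nM.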

Compound 3, half-maximal inhibitory concentration: 18400 nM
Compound 3: the middle estimate sits 1.1-fold (0.04 log units) above what was measured; the range from low to high includes it.
By their numbers in this assay, from the lowest: compound 1; then compounds 3 and 2 (each within the scatter of the next).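

Working notes: in this assay the chain is now varied on its own, with the (2-aminophenyl)carbamoyl end held fixed, and this gives a 1.1-fold lower number from compound 2 to compound 3 (0.04 log units; within the scatter), so this change at this position separates compound 2 and compound 3 by no more than the scatter. The comparison with the hydroxycarbamoyl series also holds at this chain length, with (2-aminophenyl)carbamoyl in place of 3-(hydroxycarbamoyl)propyl giving a 3.8-fold higher number from compound 1 to compound 3 (0.58 log units; beyond the scatter), a step beyond the scatter. No available measurement accounts for either step.

As far as these compounds go, whether the flat response extends to a longer chain carrying the (2-aminophenyl)carbamoyl end remains open. Also open, from the compounds shown here alone, is how a hydroxycarbamoyl or carboxylic acid end would read on the chain of compound 3, which would separate the end group from chain length.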